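Methyl Added to the Pyridine-Type Ring of a Thiosemicarbazide

A few compounds are considered here, and "the series" means these few. Any claim that something is new, unique, unknown or untested is made for them only; others in the source may bear on it.

Measured compounds and their values:
Compound 1, `Cc1cccc(/C(N)=N/NC(=S)N2CCN(c3ccccn3)CC2)n1`: 78.9%
Compound 2, `N/C(=N\NC(=S)N1CCCCCC1)c1ccccn1`: 77.5%
Compound 3, `N/C(=N\NC(=S)N1CCCCC1)c1ccccn1`: 85.6%

All three compounds were tested in a functional assay on A-431 cells (Homo sapiens) for cytotoxicity, read by MTT assay, with a stated time of 72 h, tested at 100 uM; a higher number here means more inhibition of growth at the concentration tested, a lower number less inhibition of growth. Among the three numbers, compound 2 sits at the low end with 77.5%, but the gap to compound 1 and the gap to compound 3 both lie within the usual scatter of this assay, so the three compounds cannot be told apart on these data.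

Compound 4, `Cc1ccnc(/C(N)=N/NC(=S)N2CCCCCC2)c1`, has not yet been measured. It differs from compound 2 in one place: methyl in place of hydrogen on an aromatic carbon. Compound 1 also carries a methyl group on its ring and gives a number within the scatter of compound 2, which offers no sign that such a methyl moves the read-out much. Among the compounds with values here, no measured pair shows this exact change, so the size of its effect is not known from the data.

The expectation is therefore a small step, from compound 2 to compound 4 of about a number 0.5 percentage points higher from compound 2 to compound 4 (within the scatter), not beyond the scatter. Compound 4 is estimated to give 78%, with a likely range from 66% to 90%.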

Compound 4, percent growth inhibition at one concentration: 71%
Compound 4: the middle estimate sits 7 percentage points above what was measured; the measured number falls inside the stated range.
By their numbers in this assay, from the lowest: compounds 4, 2, 1 and 3 (each within the scatter of the next, the first and the last beyond it).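

In this assay, within the data shown here, methyl in place of hydrogen on an aromatic carbon, opposite the ring nitrogen and meta to a large group, gives a number 6.5 percentage points lower from compound 2 to compound 4 (within the scatter), the first direct reading of this change at this position. The single added carbon therefore leaves the read-out at a level that cannot be told apart from that of the compound without it, so this position accepts a methyl group with no clear loss of growth inhibition in this one pair. No measurement shown bears on what lies behind the step.

Still open, as far as these compounds go, is whether the same carbon would accept something other than methyl, such as an ethyl group, an amine or a carboxylic acid, and whether any of these would produce a step beyond the scatter. Also open, from the compounds shown here alone, is whether methyl on the other carbons of this ring would behave in the same way, and whether the same change made on compound 3 would give a step of similar size.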